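This account rests on a few compounds, and the source may have more. Where it says the series, first, only, none or still open, it means among the compounds named here.

Measured compounds:
Compound 1, `CC1=CC[C@H](C(C)(C)NC(=S)N/N=C/c2ccccc2)CC1`: in a functional assay on HT-29 cells (Homo sapiens) for inhibition, read by sulforhodamine B assay, with a stated time of 48 h (a lower number here means a stronger inhibitor of growth, a higher number a weaker inhibitor of growth), compound 1 gives 22200 nM.
Compound 2, `CC1=CC[C@H](C(C)(C)NC(=S)N/N=C/c2ccccc2Cl)CC1`: in this assay compound 2 gives > 100000 nM, which is a limit of the assay and not a number.

Compound 2 therefore stands at the limit of > 100000 nM in this assay, at which 1 of the 2 values shown sits, so its place relative to compound 1 is known only as a bound: the step of an at least 4.5-fold higher number from compound 1 to compound 2 (0.65 log units; beyond the scatter) shows that chloro in place of hydrogen on an aromatic carbon weakened growth inhibition to a degree that can only be stated as a minimum. Compound 3, `CC1=CC[C@H](C(C)(C)NC(=S)N/N=C/c2ccccc2[N+](=O)[O-])CC1`, has not been measured in this assay. It differs from compound 2 by nitro in place of chloro on an aromatic carbon, the nitro sitting ortho to a large group. For the measured compounds named here, only one measured step bears on this position, and it concerns a different substituent; it establishes merely that compound 2 already sits where the assay stops reporting numbers. Going by the values given here, no measured step allows the direction of exchanging nitro for chloro to be judged. For compound 3 the step that the limit leaves unreadable from compound 2 to compound 3 is expected to be small, with the result most likely remaining a limit. Compound 3 is estimated at 150000 nM, between 40000 nM and 500000 nM.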

Compound 3, concentration for total growth inhibition: 70800 nM
Estimate against measurement, compound 3: 2.1-fold (0.33 log units) above, within the range that was stated.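

In this assay, putting nitro where the shared core carries hydrogen, ortho to a large group, gives a 3.2-fold higher number from compound 1 to compound 3 (0.50 log units; beyond the scatter), so a second group at this position, after chloro, goes with weaker growth inhibition than hydrogen. Unlike the chloro step, which could be given only as a minimum, this step has a measured value at both ends, and its size can therefore be stated. Nitro in place of chloro gives an at least 1.4-fold lower number from compound 2 to compound 3 (0.14 log units; that floor lies within the scatter), and this floor lies within the scatter, so the shown compounds do not establish that the two groups differ, because the comparison rests on a bound: the limit of > 100000 nM in this assay, at which 1 of the 3 values shown sits.

As far as these compounds go, whether this weaker inhibition extends to other groups at this position, such as an amine, a methoxy group or a carboxylic acid, remains open. So does whether chloro or nitro would give the same result on another carbon of the aromatic ring, since both groups are seen here only ortho to a large group.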